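The source may report more compounds than this note shows. Statements on the series, on what has been measured and on what is new or still open speak of the compounds shown alone.

Measured in a functional assay on NCI-H460 cells (Homo sapiens) for inhibition, with a stated time of 72 h; a higher number here means a weaker inhibitor, a lower number a stronger inhibitor:
- compound 1 `COc1ccc(S(=O)(=O)N2CCc3cccc(-c4ccco4)c32)cc1`: 94.5 nM
- compound 2 `COc1ccc(-c2cccc3c2N(S(=O)(=O)c2ccc(OC)cc2)CC3)cc1`: 302 nM
- compound 3 `COc1ccc(S(=O)(=O)N2CCc3cccc(-c4ccncc4)c32)cc1`: 101 nM

Compound 3 shares the low end of these numbers with compound 1 and lies clear of compound 2. The measurements show a 1.1-fold higher number from compound 1 to compound 3 (0.03 log units; within the scatter), and they also show a 3.0-fold lower number from compound 2 to compound 3 (0.48 log units; beyond the scatter).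

The next compound, compound 4 `COc1ccc(S(=O)(=O)N2CCc3cccc(-c4ccc(C#N)cc4)c32)cc1`, has 4-cyanophenyl in place of pyridin-4-yl on an aromatic carbon. Among the measured compounds shown here, the steps that bear on this change are those involving compound 2, the only measured compound with a substituted phenyl at this place. They are modest: a 3.2-fold higher number from compound 1 to compound 2 (0.50 log units; beyond the scatter), and the step to compound 3 given above is of similar size. For the measured compounds named here, no measured compound carries a nitrile, so this comparison is only a loose guide. A modest move toward a higher number is therefore expected in this assay, with the value perhaps not reaching that of compound 2. The expected change is a 2.2-fold higher number from compound 3 to compound 4 (0.34 log units; beyond the scatter). For compound 4 the estimated value is 220 nM, with an expected range from 80 nM to 550 nM.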

Compound 4, half-maximal inhibitory concentration: 29.5 nM
Compound 4: middle estimate off by 7.5-fold (0.87 log units), on the high side, outside the stated range (below it).
By their numbers in this assay, from the lowest: compound 4; then compounds 1 and 3 (each within the scatter of the next); then compound 2.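

In this assay a substituted phenyl at this place is no drawback in itself: cyano in place of methoxy on that phenyl gives a 10-fold lower number from compound 2 to compound 4 (1.01 log units; beyond the scatter) and is the largest step among these compounds, so the group carried by the phenyl matters a great deal. The 4-cyanophenyl also separates compound 4 from the two compounds that lie within the scatter of each other, with a 3.4-fold lower number from compound 3 to compound 4 (0.53 log units; beyond the scatter) and a 3.2-fold lower number from compound 1 to compound 4 (0.51 log units; beyond the scatter) on record, which makes compound 4 the most potent of the four here. No measurement shown explains this gain.

On these data alone, it remains open whether the nitrile would have the same effect at another place on the phenyl or on the pyridine or furan ring. As far as these compounds go, it is also open whether an amine, a carboxylic acid or a chlorine atom on the phenyl would match it.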